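A few compounds are considered here, and "the series" means these few. Any claim that something is new, unique, unknown or untested is made for them only; others in the source may bear on it.

Measured so far:
Compound 1 `COc1cc2c(cc1C(C)NC/C=C/c1ccccc1)C=CC(C)(C)O2` – in an assay on cell membranes for displacement of a labelled ligand from Sigma non-opioid intracellular receptor 1 (Cavia porcellus), read by scintillation counting (a lower number here means a stronger inhibitor, a higher number a weaker inhibitor), compound 1 gives 83 nM
Compound 2 `COc1cc2c(cc1C(C)N[C@H](C)c1ccccc1)C=CC(C)(C)O2` – in this assay compound 2 gives 232 nM

Of the two numbers in hand, compound 2 stands highest: its nearest neighbour is compound 1, whose number is lower by a margin that lies beyond the scatter of repeated runs of this kind. Compound 3 `COc1cc2c(cc1C(C)N[C@@H](C)c1ccccc1)C=CC(C)(C)O2` has not yet been measured in this assay. It differs from compound 2 only in this: the two compounds have the same atoms and bonds; at least one stereo element is drawn with a configuration in one of them and without one in the other: 1 of 2 stereo elements differ; a stereocentre at a saturated chain carbon is drawn R in compound 2 and S in compound 3. Nothing leaves and nothing enters; the whole change is the drawn configuration at that one chain carbon, while the other stereocentre stays as it was.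

Among the compounds with values here, no pair of measured compounds shows what such a change does here, so there is no step to lean on. For a change of this kind, in which the same atoms are arranged differently at a single centre, a shift in either direction is possible, and a shift beyond the scatter is just as plausible as none. The author expects compound 3 to come out near 150 nM, somewhere between 40 nM and 600 nM. That estimate means a step of a 1.5-fold lower number from compound 2 to compound 3 (0.19 log units; within the scatter), which is expected rather than known.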

Compound 3, inhibition constant: 805 nM
Compound 3: middle estimate off by 5.4-fold (0.73 log units), on the low side; measured number above the stated range.
By their numbers in this assay, from the lowest: compound 1; then compound 2; then compound 3.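

In this assay, the drawn configuration at this chain carbon proves to matter: with the atoms and bonds unchanged, moving from R to S gives a 3.5-fold higher number from compound 2 to compound 3 (0.54 log units; beyond the scatter), so the R drawing is the better of this pair. The earlier compounds shown here could not show this, since no measured pair had isolated a single centre, and this one step shows that the series responds to how the groups are arranged at that carbon as well as to which groups are present, though the step is modest in size. The record on what separates the two compounds comes down to one fact: the fact that one of compounds 2 and 3 is drawn with a defined configuration and the other without, at the place where they differ.

From the compounds shown here alone, the other stereocentre stays as it was in both compounds, so what its configuration contributes to the number remains open. Also open, going by these compounds, is whether the same gap between R and S would hold with a longer chain in place of the methyl on the changed carbon, or with an amide in place of the amine.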